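Benzothiophene for Phenyl on the Oxadiazole of Compound 3

The source may hold more compounds than are shown below. What is called first, only, known or untested is meant among the compounds shown, and "the series" means these compounds.

Compound 1 `O=S(=O)(O)CCCSC(=S)NCc1cccnc1`: 6770 nM
Compound 2 `S=C(NCc1cccnc1)SCCc1nc2ccccc2[nH]1`: 1690 nM
Compound 3 `S=C(NCc1cccnc1)SCCc1nnc(-c2ccccc2)o1`: 580 nM

Of the compounds shown here, three have been measured in a functional assay on SK-BR-3 cells (Homo sapiens) for cytotoxicity, read by resazurin assay, with a stated time of 72 h; on this read-out lower numbers stand for stronger inhibition and higher numbers for weaker inhibition. They share the thiocarbamate arm ending in the pyridinylmethyl group and differ in the ring system carried on the two-carbon chain. In this assay compound 1 gives 6770 nM, compound 2 gives 1690 nM and compound 3 gives 580 nM. Compound 3 therefore stands lowest of the three, with compound 2 nearest to it and compound 1 furthest away, both gaps lying beyond the usual scatter.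

Compound 4 `S=C(NCc1cccnc1)SCCc1nnc(-c2cc3ccccc3s2)o1` has not yet been measured. It differs from compound 3 in one place: 1-benzothiophen-2-yl in place of phenyl on an aromatic carbon. For the measured compounds named here, no step between two measured compounds reproduces this exchange, so there is no direct precedent to lean on. The enlargement of the ring system is expected to give a modest lowering in this assay, though a result within the scatter would not surprise. The step of a 1.8-fold lower number from compound 3 to compound 4 (0.26 log units; within the scatter) is the estimated size of that change. Compound 4 is thus expected to give about 320 nM, within a range from 110 nM to 950 nM.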

Compound 4, half-maximal inhibitory concentration: 5320 nM
Compound 4: middle estimate off by 17-fold (1.22 log units), on the low side; measured number outside the range, above it.
By their numbers in this assay, from the lowest: compound 3; then compound 2; then compounds 4 and 1 (each within the scatter of the next).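

In this assay, placing 1-benzothiophen-2-yl instead of phenyl on the aromatic carbon of the five-membered aromatic ring with 2 nitrogen and 1 oxygen gives a 9.2-fold higher number from compound 3 to compound 4 (0.96 log units; beyond the scatter). For the compounds shown here, this is the first step that changes only one place, and it shows that the number at this position depends strongly on the group carried there: a larger aromatic group is not simply accepted here, and in this single case the enlargement raises the number. Nothing available on these compounds accounts for the rise.

Going by these compounds alone, the single exchange leaves open whether the rise follows from the added benzene ring or from the sulfur-containing ring, which a thiophen-2-yl or a naphthalen-2-yl group at the same place could separate. It also leaves open how a fluorine or a methoxy group on the phenyl of compound 3 would fare.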